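Moving the Isopropyl Group: From Compound 2 to Compound 3

The compounds below may be only part of what the source reports. "The series", "measured", "known", "first", "only" and "open" are said of these compounds alone.

Measured so far:
Compound 1 `CO[C@H]1O[C@H](COc2ccc(OC3CCCCC3)cc2)[C@@H](O)[C@H](O)[C@H]1Oc1ccc(OC2CCCCC2)cc1` gives 14000 nM in a functional assay on HeLa cells (Homo sapiens) for cytotoxicity, read by MTT assay, with a stated time of 48 h; a lower number here means that less compound is needed, a higher number that more compound is needed for the effect.
Compound 2 `CO[C@H]1O[C@H](COc2ccc(-c3ccccc3)cc2)[C@@H](O)[C@H](O)[C@H]1Oc1ccccc1C(C)C` gives 29000 nM in this assay.

Compound 2 stands highest of these two numbers; its nearest neighbour, compound 1, sits lower by a gap beyond the scatter. Compound 3 `CO[C@H]1O[C@H](COc2ccc(-c3ccccc3)cc2)[C@@H](O)[C@H](O)[C@H]1Oc1cccc(C(C)C)c1` differs from compound 2 in one place: 3-isopropylphenyl in place of 2-isopropylphenyl on an oxygen on a saturated carbon. Within the data shown here, no step between measured compounds shows what this change does, so the expected step in this assay is small, in neither direction beyond the scatter. Compound 3 is estimated to give 25000 nM, between 8000 nM and 80000 nM, which is an expected 1.2-fold lower number from compound 2 to compound 3 (0.06 log units; within the scatter).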

Compound 3, half-maximal effective concentration: 35000 nM
Compound 3: the middle estimate sits 1.4-fold (0.15 log units) below what was measured, and the stated range covers the measured number.
By their numbers in this assay, from the lowest: compound 1; then compounds 2 and 3 (each within the scatter of the next).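

In this assay, 3-isopropylphenyl in place of 2-isopropylphenyl on this oxygen gives a 1.2-fold higher number from compound 2 to compound 3 (0.08 log units; within the scatter). Among these compounds, the two placements of the isopropyl group therefore cannot be told apart in this read-out, which the earlier compounds, with no step between them, could not show. Nothing available explains this result. On these data alone, whether a carboxylic acid or an amine in place of the isopropyl group would give a step beyond the scatter stays open. So does whether this same change would behave alike with another group at the other end of the shared core.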